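The compounds below may be only part of what the source reports. "The series", "measured", "known", "first", "only" and "open" are said of these compounds alone.

Measured in a functional assay on MOLT-4 cells (Homo sapiens); on this read-out lower numbers stand for stronger inhibition and higher numbers for weaker inhibition:
- compound 1 `CCOc1ncnc2c1ncn2C[C@@H]1C[C@H](CO)c2ccccc21`: 24 ug/mL
- compound 2 `Cn1ncc2c1[C@H](Cn1cnc3c(Cl)ncnc31)C[C@@H]2CO[Si](c1ccccc1)(c1ccccc1)C(C)(C)C`: 3.2 ug/mL
- compound 3 `Cc1cn(C[C@@H]2C[C@H](CO)c3ccccc32)c(=O)[nH]c1=O`: 81 ug/mL

Compound 1 holds the middle place among these three. Compound 3 gives a higher number and compound 2 a lower one, and both gaps lie beyond the usual scatter.

Compound 4 `OC[C@H]1C[C@@H](Cn2cnc3c(NC4CC4)ncnc32)c2ccccc21` has not been measured yet. It keeps the core of compound 1 and changes in one place: cyclopropylamino in place of ethoxy on an aromatic carbon. This puts cyclopropylamino in place of ethoxy on an aromatic carbon.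

For the measured compounds named here, no two measured compounds differ in just one place, so the data show no precedent for this swap. With no evidence for either direction, the step expected in this assay stays within the scatter: a 1.1-fold lower number from compound 1 to compound 4 (0.04 log units; within the scatter). For compound 4 the estimated value is 22 ug/mL, with an expected range from 6 ug/mL to 80 ug/mL.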

Compound 4, half-maximal inhibitory concentration: 24 ug/mL
Compound 4: middle estimate off by 1.1-fold (0.04 log units), on the low side; low and high end bracket the measured number.
By their numbers in this assay, from the lowest: compound 2; then compounds 1 and 4 (each within the scatter of the next); then compound 3.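

In this assay, for the compounds shown here, putting cyclopropylamino in place of ethoxy on this aromatic carbon gives no change at the digits printed from compound 1 to compound 4 (within the scatter) and provides the first direct comparison at this position. The read-out therefore stays put here even though the entering group adds a three-membered ring and a hydrogen-bond donor. No measurement at hand explains why the two groups read alike. The compounds shown leave open whether a plain amino group, a carboxylic acid or a longer chain such as butoxy on this carbon would also leave the number unchanged.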